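The source may hold more compounds than are shown below. What is called first, only, known or untested is meant among the compounds shown, and "the series" means these compounds.

Compound 2 `Nc1ccc(C(=O)/C=C/c2ccccc2)cc1` is the plainer of the two measured compounds, while compound 1 `O=C(/C=C/c1ccco1)c1ccc(NC(=O)c2cccs2)cc1` carries a larger amide substituent and a different ring at the far end of the shared core. In a functional assay on HCT-116 cells (Homo sapiens) for cytotoxicity, read by resazurin assay, with a stated time of 48 h (on this read-out lower numbers stand for an effect already at smaller amounts and higher numbers for an effect only at larger amounts of compound), compound 1 gives 45000 nM. In this assay compound 2 gives 23000 nM, the lowest of the two numbers, though the gap to compound 1 lies within the scatter, so neither compound can be called the more potent.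

Compound 3 `O=C(/C=C/c1ccccc1)c1ccc(NC(=O)c2cccs2)cc1` differs from compound 2 by (thiophen-2-yl)carbonyl in place of hydrogen on a nitrogen on an aromatic ring. Among the compounds with values here, no measured pair isolates this change. Compound 1 already carries the same ((thiophen-2-yl)carbonyl)amino group and, at 45000 nM, sits within the scatter of compound 2, which gives no sign of a large effect from that group. The step from compound 2 to compound 3 is therefore expected to be small, a 1.3-fold higher number from compound 2 to compound 3 (0.12 log units; within the scatter), with no direction beyond the scatter. Compound 3 is estimated at 30000 nM, within a range from 10000 nM to 90000 nM.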

Compound 3, half-maximal effective concentration: 16000 nM
For compound 3 the middle estimate is 1.9-fold (0.27 log units) above the measured one; the measured number falls inside the stated range.
By their numbers in this assay, from the lowest: compounds 3, 2 and 1 (each within the scatter of the next, the first and the last beyond it).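

On the nitrogen on an aromatic ring, (thiophen-2-yl)carbonyl in place of hydrogen gives, in this assay, a 1.4-fold lower number from compound 2 to compound 3 (0.16 log units; within the scatter), so this direct reading of the change shows no effect that stands clear of the scatter. With that amide group held constant, phenyl in place of furan-2-yl on a double-bonded chain carbon gives a 2.8-fold lower number from compound 1 to compound 3 (0.45 log units; beyond the scatter), a modest step and the only one of the two that goes beyond the scatter. Nothing measured here explains why the ring swap registers while the amide change does not.

Going by these compounds, it remains open whether a smaller group on that nitrogen, such as acetyl, would also stay within the scatter. On these data alone, it is equally open whether a pyridine ring in place of phenyl on the chain would give a lower or a higher number.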